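Fluorophenyl for Fluoropyridinyl: Half-Life Expected to Hold

The source may report more compounds than this note shows. Statements on the series, on what has been measured and on what is new or still open speak of the compounds shown alone.

Compound 1 `Cc1nc(C)c(C(=O)Nc2ccc(F)c(-c3nc4ncc(-c5cccnc5Cl)cn4n3)c2)o1`: > 1.5 h
Compound 2 `O=C(Nc1ccc(F)c(-c2nc3ncc(-c4cccnc4F)cc3[nH]2)c1)N1CCCC1`: > 1.5 h

Of the compounds shown here, two have been measured in an ADME assay on microsomes from liver (Mus musculus) for metabolic stability, read by LC-MS; on this read-out lower numbers stand for a shorter-lived compound and higher numbers for a longer-lived compound. For compound 1 the reading of > 1.5 h is a limit of the assay rather than a number. For compound 2 the reading of > 1.5 h is likewise a limit of the assay. Compound 2 therefore sits at the limit of > 1.5 h in this assay, at which 2 of the 2 values shown sit, and the data give no number beyond that limit for either compound.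

Compound 3 `O=C(Nc1ccc(F)c(-c2nc3ncc(-c4ccccc4F)cc3[nH]2)c1)N1CCCC1` differs from compound 2 in one place: 2-fluorophenyl in place of 2-fluoropyridin-3-yl on an aromatic carbon. Within the data shown here, no step between two measured compounds covers this change, so it has no measured counterpart here. In this assay the step of a number no higher from compound 2 to compound 3 (the limit leaves the size open) is expected to stay within the usual scatter, with no clear direction. Compound 3 is accordingly estimated at 1.5 h, with a plausible range from 0.7 h to 3 h, and a fair chance that only a limit is again reported.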

Compound 3, half-life: 0.172 h
Compound 3: middle estimate off by 8.7-fold (0.94 log units), on the high side; the whole stated range lies above it.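

Among these compounds, the change at this aromatic carbon, which the earlier compounds left untested, proves far from neutral. In this assay, replacing 2-fluoropyridin-3-yl with 2-fluorophenyl gives an at least 8.7-fold lower number from compound 2 to compound 3 (0.94 log units; beyond the scatter), although the heavy-atom count stays the same and the ring differs only in having carbon where the pyridine has its nitrogen. The step sets only a minimum size, because the starting reading for compound 2 is a limit and not a number: the limit of > 1.5 h in this assay, at which 2 of the 3 values shown sit.

The compounds shown do not tell how far compound 2 lies beyond its limit, nor why the ring nitrogen matters to the half-life. They also leave open whether the same step would appear with a pyrimidine ring or an unsubstituted pyridine at this position, or with the urea of compound 2 replaced by an amide.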